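The compounds below may be only part of what the source reports. "The series", "measured", "known", "first", "only" and "open" are said of these compounds alone.

Of the compounds shown here, two have been measured so far. Compound 1, `CCCCc1cn(C(c2ccccc2)c2cc3cc(Br)ccc3nc2OC)nn1`, gives 5.54% in an ADME assay on PC-3 cells (Homo sapiens) for cytotoxicity, read by sulforhodamine B assay, with a stated time of 48 h, tested at 10 uM (on this read-out higher numbers stand for more inhibition at the one concentration tested (going by the name of the read-out) and lower numbers for less inhibition), and compound 2, `CCCCCCCCc1cn(C(c2ccccc2)c2cc3cc(Br)ccc3nc2OC)nn1`, gives 2.27% in this assay. Within the data shown here, the single step between them, a number 3.3 percentage points lower from compound 1 to compound 2 (within the scatter), comes from butyl in place of hydrogen on the chain and lies within the scatter. Compound 2 holds the lower of the two numbers shown, but its nearest neighbour, compound 1, stands only that small step away, so the two cannot be told apart. The next compound, compound 3, `CCOC(=O)c1cn(C(c2ccccc2)c2cc3cc(Br)ccc3nc2OC)nn1`, differs from compound 2 by ethoxycarbonyl in place of octyl on an aromatic carbon. Among the measured compounds shown here, no measured step involves an ethoxycarbonyl group, so the only guide is that the one known step was small and both numbers sit near the bottom of the scale. The step from compound 2 to compound 3 is therefore expected to be a number 1.7 percentage points higher from compound 2 to compound 3 (within the scatter), within the scatter. For compound 3 the estimate is 4%, ranging from -6% to 14%.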

Compound 3, a percentage reported as inhibition, at one concentration (the size of the read-out at that concentration, not a potency): 16.1%
For compound 3 the middle estimate is 12.1 percentage points below the measured one, outside the stated range (above it).
By their numbers in this assay, from the lowest: compounds 2 and 1 (each within the scatter of the next); then compound 3.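

On the aromatic carbon of the five-membered ring, the type of group matters in a way that the earlier pair could not show: ethoxycarbonyl in place of octyl gives a number 13.8 percentage points higher from compound 2 to compound 3 (beyond the scatter) in this assay, and ethoxycarbonyl in place of butyl gives a number 10.6 percentage points higher from compound 1 to compound 3 (beyond the scatter) as the same kind of modest move. Octyl and butyl themselves stay within the scatter of each other, so among these three compounds only the change from a saturated chain to ethoxycarbonyl separates the numbers. Nothing available explains this step.

From the compounds shown here alone, it remains open whether the carbonyl, the ethyl part or the loss of the chain carries the step. A carboxylic acid, an amide or a methyl group on this same carbon would help to separate these possibilities.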